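Extending the Side Chain of Compound 1

This account rests on a few compounds, and the source may have more. Where it says the series, first, only, none or still open, it means among the compounds named here.

Compound 1 `CCCCCC(O)C1=CC(=O)c2c(OC)ccc(OC)c2C1=O` was tested in a functional assay on L1210 cells (Mus musculus) for cytotoxicity (a higher number here means that more compound is needed for the effect, a lower number that less compound is needed), and gave 0.378 ug/mL. For the measured compounds named here, of the two numbers measured so far it is the highest; compound 2 `CCCCCCC(O)c1cc(OC)c2c(c1OC)C(=O)C=CC2=O` gave 0.22 ug/mL in this assay, a result within the scatter of that of compound 1. Compound 3 `CCCCCCCC(O)C1=CC(=O)c2c(OC)ccc(OC)c2C1=O` has not yet been measured. It differs from compound 1 by ethyl in place of hydrogen on a saturated chain carbon, six bonds along the chain from a double-bonded ring carbon and an oxygen on a saturated carbon. Going by the values given here, no step between measured compounds of this kind is known, so the data give no size for such a change; compound 3 is expected to stay close to compound 1, with an expected step of a 1.3-fold lower number from compound 1 to compound 3 (0.10 log units; within the scatter) not beyond the scatter. Compound 3 is estimated at 0.3 ug/mL, in the range 0.1 ug/mL to 0.9 ug/mL.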

Compound 3, concentration for half-maximal effect: 1.04 ug/mL
Estimate against measurement, compound 3: 3.5-fold (0.54 log units) below; measured number above the stated range.
By their numbers in this assay, from the lowest: compounds 2 and 1 (each within the scatter of the next); then compound 3.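

In this assay ethyl in place of hydrogen on this saturated chain carbon now has a measured size (a 2.8-fold higher number from compound 1 to compound 3 (0.44 log units; beyond the scatter)), a modest step but one beyond the scatter. For the compounds shown here, this single step shows that extending the chain here means more compound is needed for the effect, which the earlier compounds could not show. Nothing available bears on the reason for this rise. As far as these compounds go, whether a longer chain would raise the number further stays open. So does the effect of an amine or a carboxylic acid at the end of this chain.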